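Swapping a hydroxybutynyl chain for an ethyl pyrazole

The source may hold more compounds than are shown below. What is called first, only, known or untested is meant among the compounds shown, and "the series" means these compounds.

Compound 1 `CC(C)(O)C#Cc1cc(C(O)(C(F)(F)F)C(F)(F)F)cnc1N1CCN(S(=O)(=O)c2ccc(N)nc2)CC1` gives 16 mL.min-1.g-1
Compound 2 `Nc1ccc(S(=O)(=O)N2CCN(c3ncc(C(O)(C(F)(F)F)C(F)(F)F)cc3C#CCCO)CC2)cn1` gives 68 mL.min-1.g-1

In an ADME assay (liver) for metabolic stability, with Liver microsome (Rattus norvegicus) as the target, using microsomes and NADPH, with a stated time of 30 min, tested at 1 uM (a lower number here means slower removal, a higher number faster removal of the compound), compound 2 holds the higher of the two numbers (68 mL.min-1.g-1) and so is removed faster than compound 1. Within the data shown here, the one measured step (a 4.3-fold higher number from compound 1 to compound 2 (0.63 log units; beyond the scatter)) puts 2-hydroxyethyl in place of 1-hydroxy-1-methylethyl on a triple-bonded carbon, and it is modest but beyond the scatter.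

Compound 3 (`CCn1cc(-c2cc(C(O)(C(F)(F)F)C(F)(F)F)cnc2N2CCN(S(=O)(=O)c3ccc(N)nc3)CC2)cn1`) changes that same place again (1-ethyl-1H-pyrazol-4-yl in place of 4-hydroxybut-1-yn-1-yl on an aromatic carbon), with 1-ethyl-1H-pyrazol-4-yl in place of 4-hydroxybut-1-yn-1-yl on an aromatic carbon. This time the triple bond goes as well, so the measured step is only a loose guide. It does show that a change here can shift the number by a modest amount. Compound 2 also sits at the top of a very small set, so a move back towards compound 1 (16 mL.min-1.g-1) seems more likely than a further rise, though neither direction is secure. The estimated step is a 1.7-fold lower number from compound 2 to compound 3 (0.23 log units; within the scatter) (expected to be a modest fall). For compound 3 the estimated value is 40 mL.min-1.g-1 (expected range 14 mL.min-1.g-1 to 110 mL.min-1.g-1).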

Compound 3, intrinsic clearance in microsomes: 194 mL.min-1.g-1
Estimate against measurement, compound 3: 4.9-fold (0.69 log units) below; measured number outside the range, above it.
By their numbers in this assay, from the lowest: compound 1; then compound 2; then compound 3.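

In this assay the two hydroxylated alkyne chains had shown only a modest spread at this position, but a ring widens it. Putting 1-ethyl-1H-pyrazol-4-yl in place of 4-hydroxybut-1-yn-1-yl gives a 2.9-fold higher number from compound 2 to compound 3 (0.46 log units; beyond the scatter), and putting it in place of 3-hydroxy-3-methylbut-1-yn-1-yl gives a 12-fold higher number from compound 1 to compound 3 (1.08 log units; beyond the scatter), so the group on this aromatic carbon, ortho to a large group, can produce a large change in removal and not just a modest one. Nothing available here explains why the number rises with the pyrazole.

This single change removes the triple bond and the hydroxyl and brings in an aromatic ring all at once, so the three compounds cannot show which of these matters for the higher number. A pyrazole carrying a 2-hydroxyethyl group on its nitrogen, or one with a methyl in place of the ethyl, would help to separate those parts.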